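A Chloro Added to the Phenyl Ring of Compound 3

A few compounds are considered here, and "the series" means these few. Any claim that something is new, unique, unknown or untested is made for them only; others in the source may bear on it.

- compound 1 `C/C1=C\CC[C@@]2(C)O[C@@H]2[C@H]2OC(=O)[C@@H](CN3CCCCC3)[C@@H]2C[C@@H]1O` gives 6000 nM
- compound 2 `C[C@]12O[C@@H]1CC[C@@]1(C)O[C@@H]1[C@H]1OC(=O)[C@@H](CN3CCCCC3)[C@@H]1C[C@H]2O` gives 46000 nM
- compound 3 `C[C@]12O[C@@H]1CC[C@@]1(C)O[C@@H]1[C@H]1OC(=O)[C@@H](CN3CCN(c4ccccc4)CC3)[C@@H]1C[C@H]2O` gives 22000 nM

These three numbers come from a functional assay on B16-F10 cells (Mus musculus) for inhibition, read by colorimetric assay and MTT assay, with a stated time of 72 h (a higher number here means a weaker inhibitor, a lower number a stronger inhibitor), and all describe weak inhibitors. Compound 3 sits in the middle. Its number is lower than that of compound 2 and higher than that of compound 1, and both gaps lie beyond the scatter. The next compound, compound 4 `C[C@]12O[C@@H]1CC[C@@]1(C)O[C@@H]1[C@H]1OC(=O)[C@@H](CN3CCN(c4ccc(Cl)cc4)CC3)[C@@H]1C[C@H]2O`, keeps everything in compound 3 except one spot: chloro in place of hydrogen on an aromatic carbon, para to a large group, so phenyl becomes 4-chlorophenyl.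

Going by the values given here, no measured pair shows this change, so the only firm anchor is compound 3 at 22000 nM in this assay. A single added atom on the outer ring is therefore expected to give, at most, a small drop in the number, probably none beyond the scatter. The estimated step is a 1.2-fold lower number from compound 3 to compound 4 (0.09 log units; within the scatter) and it remains uncertain. Compound 4 is expected at about 18000 nM (estimated range 7000 nM to 45000 nM).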

Compound 4, half-maximal inhibitory concentration: 19000 nM
Beside the measured number, compound 4's estimate is 1.1-fold (0.02 log units) below it; the measured number falls inside the stated range.
By their numbers in this assay, from the lowest: compound 1; then compounds 4 and 3 (each within the scatter of the next); then compound 2.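

Before this result, no compound showed what happens when something is added to the outer phenyl ring. In this assay the change from phenyl to 4-chlorophenyl gives a 1.2-fold lower number from compound 3 to compound 4 (0.06 log units; within the scatter) and so produces no readable difference, which means that this aromatic carbon, para to a large group, can carry a chloro without a measurable shift in this read-out. No outside data bear on this result, so it stands as an observation without an explanation.

Going by these compounds, one chloro at one position says little about the ring as a whole, so it remains open whether an amine, a carboxylic acid or a methoxy group on the same carbon would also leave the number in place. On these data alone, it is also open whether 4-chlorophenyl would behave the same way on the core of compound 1.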